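Aryl piperazine sulfonamides on the shared core: A3 binding

A few compounds are considered here, and "the series" means these few. Any claim that something is new, unique, unknown or untested is made for them only; others in the source may bear on it.

Measured so far:
- Compound 1 `CCCn1c(=O)[nH]c2nc(-c3ccc(S(=O)(=O)N4CCN(c5ccc(Cl)cc5F)CC4)cc3)[nH]c2c1=O`: in an assay on CHO cells for displacement of a labelled ligand from adenosine receptor A3 (Homo sapiens), read by scintillation counting, with a stated time of 45 min, in the presence of a further agent that is not named here (a higher number here means a weaker inhibitor, a lower number a stronger inhibitor), compound 1 gives only a limit, > 1000 nM.
- Compound 2 `CCCn1c(=O)[nH]c2nc(-c3ccc(S(=O)(=O)N4CCN(c5ccc(Br)cc5)CC4)cc3)[nH]c2c1=O`: in this assay compound 2 gives only a limit, > 1000 nM.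
- Compound 3 `CCCn1c(=O)[nH]c2nc(-c3ccc(S(=O)(=O)N4CCN(c5ccccc5C)CC4)cc3)[nH]c2c1=O`: in this assay compound 3 gives only a limit, > 1000 nM.

Compound 3 therefore stands nowhere in particular on the numbers shown: its value in this assay is a limit, and the two other values are limits as well, so no ranking among the three is possible.

Compound 4 `CCCn1c(=O)[nH]c2nc(-c3ccc(S(=O)(=O)N4CCN(c5cccc(Cl)c5)CC4)cc3)[nH]c2c1=O` differs from compound 3 in the aryl group on the piperazine: 3-chlorophenyl in place of 2-methylphenyl on an amine nitrogen in a ring.

The measured steps that touch the same position are a step that the two limits leave unreadable from compound 2 to compound 3 and a step that the two limits leave unreadable from compound 1 to compound 3, and both are left unreadable because of the limit of > 1000 nM in this assay, at which 3 of the 3 values shown sit. The step that the two limits leave unreadable from compound 1 to compound 2 is unreadable for the same reason. Within the data shown here, no measured step therefore gives a direction or a size for the change to 3-chlorophenyl; the only pattern seen is that every aryl group tried at this position so far has left the value in this assay at its limit.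

Expectation for compound 4: the value in this assay is estimated at 3000 nM, with a range from 700 nM to 30000 nM, most likely again as a limit. The expected step is a step that the limit leaves unreadable from compound 3 to compound 4, in effect none beyond the scatter.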

Compound 4, inhibition constant: 53.5 nM
For compound 4 the middle estimate is 56-fold (1.75 log units) above the measured one; the measured number lies below the stated range.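

This position is not silent in this assay: with 3-chlorophenyl on the amine nitrogen in a ring, the series gives an at least 18-fold lower number from compound 3 to compound 4 (1.27 log units; beyond the scatter), and the other two aryl groups yield an at least 18-fold lower number from compound 2 to compound 4 (1.27 log units; beyond the scatter) and an at least 18-fold lower number from compound 1 to compound 4 (1.27 log units; beyond the scatter). The 2-methylphenyl that leaves and the 3-chlorophenyl that enters match in heavy-atom count, aromatic ring, donors, acceptors and charge, so these counts do not separate compound 3 from compound 4. Each of the three steps is a bound and not a full size, and the steps among compound 1, compound 2 and compound 3 cannot be read, because of the shared limit: the limit of > 1000 nM in this assay, at which 3 of the 4 values shown sit.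

From the compounds shown here alone, whether the step belongs to the chlorine itself or to where it sits on the phenyl ring stays open, since each of the other aryl groups differs from 3-chlorophenyl in more than one feature. Also open, going by these compounds, is how a methoxyphenyl or a cyanophenyl group would behave at this position, and so whether 3-chlorophenyl is an isolated case or part of a wider trend.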